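The source may report more compounds than this note shows. Statements on the series, on what has been measured and on what is new or still open speak of the compounds shown alone.

Series notes, step from compound 3 to compound 4.

In a functional assay on HT-29 cells (Homo sapiens) for cytotoxicity, read by MTT assay, with a stated time of 48 h, tested at 100 uM (a lower number here means a weaker effect, a higher number a stronger effect of the compound at the concentration tested), compound 3 `CS(=O)(=O)c1ccc(Cc2nnc3n2N=C(c2ccc(Cl)cc2Cl)CS3)cc1` gives 31%, the lowest of the three numbers shown. Compound 1 `CS(=O)(=O)c1ccc(Cc2nnc3n2N=C(c2cc(Cl)sc2S(N)(=O)=O)CS3)cc1` gives 35.2%, and the gap a number 4.2 percentage points lower from compound 1 to compound 3 (within the scatter) lies within the scatter. Compound 2 `CS(=O)(=O)c1ccc(Cc2nnc3n2N=C(c2cc(Cl)sc2Cl)CS3)cc1` gives 47.3%, and the gap a number 16.3 percentage points lower from compound 2 to compound 3 (beyond the scatter) is beyond it; within the same pair of thiophene-bearing compounds the step of a number 12.1 percentage points higher from compound 1 to compound 2 (beyond the scatter) is also beyond the scatter.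

Compound 4 `CS(=O)(=O)c1ccc(Cc2nnc3n2N=C(c2ccc(O)c(C(N)=O)c2)CS3)cc1` is not yet measured. Its change from compound 3 is 3-carbamoyl-4-hydroxyphenyl in place of 2,4-dichlorophenyl on a carbon with a double bond to nitrogen. No measured step exchanges a dichlorophenyl for a ring carrying a carbamoyl and a hydroxyl, so the bearing of the shown steps is indirect. The step from compound 1 to compound 2, which took a sulfamoyl out and put a chloro in, raised the number; the present change runs the other way, taking chlorines out and bringing hydrogen-bond donors and acceptors in. A small fall, or no step beyond the scatter, is therefore expected: a number 5 percentage points lower from compound 3 to compound 4 (within the scatter). Compound 4 is estimated at 26%, with a range from 12% to 40%.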

Compound 4, a percentage reported as activity, at one concentration (the size of the read-out at that concentration, not a potency): 37.1%
The estimate for compound 4 lay 11.1 percentage points below the measured number, within the range that was stated.
By their numbers in this assay, from the lowest: compounds 3, 1 and 4 (each within the scatter of the next); then compound 2.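

In this assay the step of a number 6.1 percentage points higher from compound 3 to compound 4 (within the scatter) shows that the carbon with a double bond to nitrogen can carry 3-carbamoyl-4-hydroxyphenyl, with its hydrogen-bond donors and acceptors, in place of 2,4-dichlorophenyl, which has none, without a change beyond the scatter. The step of a number 1.9 percentage points higher from compound 1 to compound 4 (within the scatter) adds that the new ring is also not separated from 5-chloro-2-sulfamoylthiophen-3-yl, so three different rings on this carbon cannot be told apart in this read-out. Only 2,5-dichlorothiophen-3-yl stands apart, and the step of a number 10.2 percentage points lower from compound 2 to compound 4 (beyond the scatter) extends that modest separation to the new ring.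

Open, as far as these compounds go, is whether an amine or a carboxylic acid in place of the carbamoyl would shift the number, and what the hydroxyl and carbamoyl each contribute alone. No evidence at hand accounts for these numbers.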